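A few compounds are considered here, and "the series" means these few. Any claim that something is new, unique, unknown or untested is made for them only; others in the source may bear on it.

Measured so far in a functional assay on MCF7 cells (Homo sapiens) for cytotoxicity, read by MTT assay, with a stated time of 48 h; on this read-out higher numbers stand for weaker inhibition and lower numbers for stronger inhibition:
- compound 1 `CC(=NNC(=S)Nc1ccccc1F)c1ccccn1`: 0.39 nM
- compound 2 `CC(=NNC(=S)Nc1ccccc1)c1ccccn1`: 0.18 nM
- compound 3 `C/C(=N/NC(=S)Nc1ccccc1I)c1ccccn1`: 4.1 nM

Among these three, compound 3 has the highest number and so is the weakest inhibitor, with compound 1 and compound 2 both lower by more than the usual scatter. The next compound is compound 4 `CC(=NNC(=S)Nc1ccccc1I)c1ccccn1`, and it differs from compound 3 only in how one double bond is drawn: the two compounds have the same atoms and bonds; at least one stereo element is drawn with a configuration in one of them and without one in the other: 1 of 1 stereo elements differ; a double bond is drawn Z in compound 3 and without a configuration in compound 4. Going by the values given here, the one measured step, a 2.2-fold lower number from compound 1 to compound 2 (0.34 log units; beyond the scatter), swaps a fluoro for a hydrogen. Among the compounds with values here, that is a different kind of change, so it offers no direct guide here, and no measured pair tests a drawn configuration. With the same atoms and bonds, the best anchor is compound 3 at 4.1 nM, and no step beyond the scatter is expected in this assay. The estimated step is a 1.2-fold lower number from compound 3 to compound 4 (0.07 log units; within the scatter). Compound 4 is expected at about 3.5 nM, with an estimated range of 1.2 nM to 8 nM.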

Compound 4, half-maximal inhibitory concentration: 4.1 nM
Estimate against measurement, compound 4: 1.2-fold (0.07 log units) below; low and high end bracket the measured number.
By their numbers in this assay, from the lowest: compound 2; then compound 1; then compounds 3 and 4 (each within the scatter of the next).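

In this assay the new result shows no change at the digits printed from compound 3 to compound 4 (within the scatter) and the two entries differ only in this: the fact that one of compounds 3 and 4 is drawn with a defined configuration and the other without, at the place where they differ. Compound 4 is drawn without a configuration, as compounds 1 and 2 are, so the iodo group can now be compared with them at one place only: iodo replaces hydrogen with a 23-fold higher number from compound 2 to compound 4 (1.36 log units; beyond the scatter) and iodo replaces fluoro with an 11-fold higher number from compound 1 to compound 4 (1.02 log units; beyond the scatter). The high number therefore goes with the iodo group and not with how the double bond is drawn in compound 3.

Since compound 4 has no stated configuration, these numbers cannot say whether a compound drawn with the opposite double-bond form would match it. On these data alone, how a chloro, bromo or methoxy group would compare on the same aromatic carbon also stays open.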